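Swapping a nitro group for isopropoxy at the outer ring

This account rests on a few compounds, and the source may have more. Where it says the series, first, only, none or still open, it means among the compounds named here.

Two compounds share a core and differ only in where a nitro group sits on the outer ring. Compound 1 `COc1cccc(OC)c1OCCNCCOc1ccccc1OCc1cccc([N+](=O)[O-])c1` gives 8.74 in a functional assay on spleen for antagonist activity at Alpha-1B adrenergic receptor (Rattus norvegicus); a lower number here means a less potent compound, a higher number a more potent compound, by a factor of ten per unit of this negative logarithm. Compound 2 `COc1cccc(OC)c1OCCNCCOc1ccccc1OCc1ccc([N+](=O)[O-])cc1` gives 9.02 in the same assay, a step of a number 0.28 log units higher from compound 1 to compound 2 (within the scatter). Compound 2 therefore holds the higher of the two numbers, but the gap is within the scatter, so the two cannot be ranked.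

Compound 3 `COc1cccc(OC)c1OCCNCCOc1ccccc1OCc1ccc(OC(C)C)cc1` differs from compound 2 by isopropoxy in place of nitro on an aromatic carbon. Within the data shown here, no measured step replaces the nitro group; the single known step only moved it, and that step was within the scatter. There is thus no basis for expecting a large shift in this assay in either direction, and the estimate stays close to compound 2 with a wide range. Compound 3 is expected to give 8.8, between 8.2 and 9.4. The expected step is a number 0.22 log units lower from compound 2 to compound 3 (within the scatter), none beyond the scatter.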

Compound 3, negative logarithm of the antagonist equilibrium constant: 8.62
For compound 3 the middle estimate is 0.18 log units above the measured one; the range from low to high includes it.
By their numbers in this assay, from the lowest: compounds 3, 1 and 2 (each within the scatter of the next, the first and the last beyond it).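

In this assay, among these compounds, isopropoxy in place of nitro on this aromatic carbon, para to a large group, gives a number 0.40 log units lower from compound 2 to compound 3 (beyond the scatter), the first step in this set to pass beyond the usual scatter, though only modestly. The nitro group is therefore not essential for a number of this size, since compound 3, which has no nitrogen in that group, still gives 8.62. Going instead from 3-nitrophenyl to 4-isopropoxyphenyl gives a number 0.12 log units lower from compound 1 to compound 3 (within the scatter), so those two groups cannot be ranked, and the effect of this change depends on which nitro compound serves as the reference.

Nothing measured here explains the step. Also open, going by these compounds, is how an amine, a carboxylic acid or a longer alkoxy chain on the same aromatic carbon would read in this assay.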